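Chloro to bromo on the aryl ketone of the vinyl sulfone series

A few compounds are considered here, and "the series" means these few. Any claim that something is new, unique, unknown or untested is made for them only; others in the source may bear on it.

All numbers come from a functional assay on DU-145 cells (Homo sapiens) for inhibition, read by trypan blue exclusion, with a stated time of 96 h; a higher number here means a weaker inhibitor of growth, a lower number a stronger inhibitor of growth.

Measured so far:
compound 1, `Cc1ccc(S(=O)(=O)/C(=C/c2sccc2C)C(=O)c2ccc(Cl)cc2)cc1`, gives 10000 nM.
compound 2, `Cc1ccc(S(=O)(=O)/C(=C/c2sccc2C)C(=O)c2ccc(Br)cc2)cc1`, gives 25000 nM.
compound 3, `O=C(/C(=C\c1ccc(F)cc1F)S(=O)(=O)c1ccc(Cl)cc1)c1ccc(Br)cc1`, gives 25000 nM.

Compound 1 and compound 2 share a core and differ in one place: bromo in place of chloro on an aromatic carbon. This change gave a 2.5-fold higher number from compound 1 to compound 2 (0.40 log units; beyond the scatter), a modest weakening that lies beyond the scatter.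

Compound 3 carries a different core; the difference between the two cores is not broken down here. Its value is level with that of compound 2 at the digits printed, so the two are within the scatter of each other, and it sits a modest step from compound 1 in the direction of a weaker inhibitor.

Compound 4, `O=C(/C(=C\c1ccc(F)cc1F)S(=O)(=O)c1ccc(Br)cc1)c1ccc(Br)cc1`, is not yet measured. It differs from compound 3 by bromo in place of chloro on an aromatic carbon. The place is described in the same words as for the change from compound 1 to compound 2, so this is the same change made on the core of compound 3.

Within the data shown here, with only one earlier instance of the change, the expectation for compound 4 rests on that single step: a weakening of about the same size, a 2.0-fold higher number from compound 3 to compound 4 (0.30 log units; within the scatter), is expected, because of a 2.5-fold higher number from compound 1 to compound 2 (0.40 log units; beyond the scatter). Compound 4 is therefore estimated at 50000 nM in this assay, with a range from 20000 nM to 130000 nM, and with a real chance that the assay reports only a limit at this level.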

Compound 4, concentration for 50% growth inhibition: 7500 nM
For compound 4 the middle estimate is 6.7-fold (0.82 log units) above the measured one, outside the stated range (below it).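

In this assay, bromo in place of chloro gives a 3.3-fold lower number from compound 3 to compound 4 (0.52 log units; beyond the scatter), a modest gain in growth inhibition, while the same change on the core of compound 1 goes the other way: the same change on two cores in this assay, a 2.5-fold higher number (0.40 log units; beyond the scatter) from compound 1 to compound 2 and a 3.3-fold lower number (0.52 log units; beyond the scatter) from compound 3 to compound 4, 8.3-fold (0.92 log units) apart, beyond the scatter of two such steps

The effect of this halogen exchange therefore does not carry from one core to the other in these two pairs, in direction or in size, and a step read on one of these cores gives no usable forecast for the other. The data do not show which of the several differences between the two cores goes with the reversal, and two pairs cannot establish a rule for the wider series or say which core is the exception.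

Still open, as far as these compounds go, is how fluoro, iodo, methoxy or an amine would read in place of the halogen of the 4-chlorophenyl group on each core, and whether they would follow compound 2 or compound 4 in direction. Also open, from the compounds shown here alone, is whether a carboxylic acid or a longer chain at that place would keep the two cores apart, and a further matched pair on a third core would be needed to show which of the two steps is more typical of the series.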